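Changing Ethyl to Methylsulfanyl on a Shared Core

This account rests on a few compounds, and the source may have more. Where it says the series, first, only, none or still open, it means among the compounds named here.

Measured so far in an in vitro ADME assay on microsomes from liver (Homo sapiens) for metabolic stability, with a stated time of 15 min; on this read-out lower numbers stand for slow clearance and higher numbers for fast clearance:
- Compound 1 `COCc1cc(OC)c(-c2cccc3c(N(CC4CCOCC4)CC4CC4)c(C#N)nn23)c(OC)c1` gives 1100 mL.min-1.g-1
- Compound 2 `CCc1nn2c(-c3c(OC)cc(COC)cc3OC)cccc2c1N(CC1CCOCC1)CC1CC1` gives 300 mL.min-1.g-1

Of these two compounds, compound 2 has the lower number, 300 mL.min-1.g-1, so it is the slower cleared of the pair. The next compound, compound 3 `COCc1cc(OC)c(-c2cccc3c(N(CC4CCOCC4)CC4CC4)c(SC)nn23)c(OC)c1`, keeps everything else and makes one small swap: methylsulfanyl in place of ethyl on an aromatic carbon.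

Going by the values given here, only one measured step bears on this swap, and it concerns the same carbon: a 3.7-fold lower number from compound 1 to compound 2 (0.56 log units; beyond the scatter). That step is modest but beyond the scatter, and it shows that the group at this carbon can shift the number. It says nothing direct about methylsulfanyl, which has not been measured here. With just two values to go on, only a small upward drift is expected, and the direction is uncertain. The estimated change is a 1.3-fold higher number from compound 2 to compound 3 (0.12 log units; within the scatter), which would not stand clear of the scatter. Compound 3 is expected at about 400 mL.min-1.g-1. The estimated range for compound 3 runs from 170 mL.min-1.g-1 to 900 mL.min-1.g-1.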

Compound 3, intrinsic clearance in microsomes: 340 mL.min-1.g-1
For compound 3 the middle estimate is 1.2-fold (0.07 log units) above the measured one; low and high end bracket the measured number.
By their numbers in this assay, from the lowest: compounds 2 and 3 (each within the scatter of the next); then compound 1.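

In this assay, ethyl and methylsulfanyl on this aromatic carbon cannot be told apart: the swap amounts to (a 1.1-fold higher number from compound 2 to compound 3 (0.05 log units; within the scatter)), so replacing a carbon with a sulfur in this two-atom group leaves the read-out within the usual scatter. The comparison with the cyano compound adds a second measured replacement at the same carbon, with methylsulfanyl in place of cyano giving (a 3.2-fold lower number from compound 1 to compound 3 (0.51 log units; beyond the scatter)), a modest step of similar size to the one seen with ethyl (a 3.7-fold lower number from compound 1 to compound 2 (0.56 log units; beyond the scatter)). Among these three compounds, then, cyano is the group that stands apart, while ethyl and methylsulfanyl sit together at the slower-cleared end, and no compound shown goes against this. Nothing measured here explains why the numbers fall this way.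

From the compounds shown here alone, it remains open whether an amine, a longer chain such as propyl, or a carboxylic acid at this carbon would sit with ethyl and methylsulfanyl or with cyano. All three compounds also share the rest of the structure, so whether the same grouping would hold on a different core cannot be told from them.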